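This account rests on a few compounds, and the source may have more. Where it says the series, first, only, none or still open, it means among the compounds named here.

Compound 1 `CC1CCN(c2nc(C(F)(F)F)ccc2CNC(=O)C(C)c2ccc(NS(N)(=O)=O)c(F)c2)CC1` gives 2.7 nM in an assay on cells for antagonist activity at transient receptor potential cation channel subfamily V member 1 (Homo sapiens), read by FLIPR and calcium flux, with a stated time of 15 min; on this read-out lower numbers stand for stronger inhibition and higher numbers for weaker inhibition. Compound 2 `CC1CCN(c2nc(C(F)(F)F)ccc2CNC(=O)C(C)c2ccc(NS(=O)(=O)N(C)C)c(F)c2)CC1`, which carries a dimethylamino in place of the amino on the sulfonyl sulfur, gives 42 nM in this assay; that is the step of a 16-fold higher number from compound 1 to compound 2 (1.19 log units; beyond the scatter). Among the two numbers measured so far, compound 2 therefore stands highest, with compound 1 as its only neighbour far below it.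

Compound 3 `C=CC(=O)N(c1ccc(C(C)C(=O)NCc2ccc(C(F)(F)F)nc2N2CCC(C)CC2)cc1F)S(C)(=O)=O` differs from compound 2 in one place: (methylsulfonyl)(vinylcarbonyl)amino in place of (dimethylsulfamoyl)amino on an aromatic carbon. Within the data shown here, the only measured step that bears on this position is a 16-fold higher number from compound 1 to compound 2 (1.19 log units; beyond the scatter), a large rise when the donor hydrogens on that nitrogen were replaced. The group entering in compound 3 again has no hydrogen-bond donor, so a number near that of compound 2 or somewhat higher is expected rather than a return towards compound 1. The expected step is a 1.7-fold higher number from compound 2 to compound 3 (0.22 log units; within the scatter). For compound 3 the estimate in this assay is 70 nM, within a range from 15 nM to 350 nM.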

Compound 3, inhibition constant: 2.4 nM
Compound 3: middle estimate off by 29-fold (1.46 log units), on the high side, and the stated range ends above it.
By their numbers in this assay, from the lowest: compounds 3 and 1 (each within the scatter of the next); then compound 2.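

In this assay, swapping the (dimethylsulfamoyl)amino group for (methylsulfonyl)(vinylcarbonyl)amino gives an 18-fold lower number from compound 2 to compound 3 (1.24 log units; beyond the scatter), so this position can take a larger group and still reach a low number, even though the entering group counts 0 hydrogen-bond donors. Set against the small sulfamoylamino group, the same change gives a 1.1-fold lower number from compound 1 to compound 3 (0.05 log units; within the scatter), which means these two very different groups cannot be told apart in this test. Nothing available here explains why the new group performs so well.

The methylsulfonyl and the vinylcarbonyl arrive together in compound 3, so the compounds shown leave open which of the two matters. An acetyl group in place of the vinylcarbonyl, or a simple methylsulfonylamino group, would help separate their contributions.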